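Swapping an Aromatic Halogen on a Bile Acid Receptor Agonist

A few compounds are considered here, and "the series" means these few. Any claim that something is new, unique, unknown or untested is made for them only; others in the source may bear on it.

Of the compounds shown here, two that share one core have been measured in an assay on isolated protein for agonist activity at Bile acid receptor (Homo sapiens), read by AlphaScreen, with a stated time of 30 min; a higher number here means that more compound is needed for the effect, a lower number that less compound is needed. Compound 1 `Cc1ccc(-n2nc(C)c3c2NC(=O)[C@H](C)S[C@@H]3c2ccc(Oc3ccccc3)cc2)cc1` gives 3400 nM in this assay. Compound 2 `Cc1nn(-c2ccccc2I)c2c1C(c1ccc(Oc3ccccc3)cc1)SC(C)C(=O)N2` gives 1300 nM in this assay. Among the measured compounds shown here, of the two numbers, compound 2 holds the lower one, and its only neighbour is compound 1, whose number is higher by a margin beyond the usual scatter. The next compound, compound 3 `Cc1nn(-c2ccccc2Cl)c2c1C(c1ccc(Oc3ccccc3)cc1)SC(C)C(=O)N2`, has not yet been measured. It differs from compound 2 in one place: chloro in place of iodo on an aromatic carbon, the change sitting ortho to a large group, or, read one bond further out, 2-iodophenyl to 2-chlorophenyl. For the measured compounds named here, no pair of measured compounds shows this change, so no measured step can guide the expectation, and the account rests on the two numbers alone. Exchanging one halogen for another on an aromatic carbon is expected to move this assay only modestly, if at all, and the step from compound 2 to compound 3 is estimated at a 1.5-fold higher number from compound 2 to compound 3 (0.19 log units; within the scatter). Compound 3 is therefore expected to give about 2000 nM in this assay, with a likely range from 800 nM to 5000 nM.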

Compound 3, half-maximal effective concentration: 2700 nM
The estimate for compound 3 lay 1.4-fold (0.13 log units) below the measured number; the measured number falls inside the stated range.
By their numbers in this assay, from the lowest: compound 2; then compounds 3 and 1 (each within the scatter of the next).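

In this assay, among the compounds shown here, the change from iodo to chloro on an aromatic carbon, ortho to a large group, gives a 2.1-fold higher number from compound 2 to compound 3 (0.32 log units; beyond the scatter) and so provides the first measured step at this position. The step is modest but lies beyond the scatter, so the choice of halogen here is not neutral: of this pair, the 2-iodophenyl compound needs less compound for the effect than the 2-chlorophenyl compound. Nothing at hand explains the difference between these two halogens, and the step stands as an observation only.

With only iodo and chloro compared at this place, two points cannot show a trend, and the compounds shown leave open how bromo or fluoro would read, and whether a group outside the halogens, such as methyl, methoxy or an amine, would give a lower number than compound 2 does. Going by these compounds, compounds 2 and 3 are also drawn without stated stereochemistry, unlike compound 1, so it remains open whether the step would keep its size between single stereoisomers.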